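Methyl-to-hydrogen on the aryl oxygen of compound 1

The source may report more compounds than this note shows. Statements on the series, on what has been measured and on what is new or still open speak of the compounds shown alone.

Compound 1 `COc1cc(C)cc(-c2nn(CC#N)cc2-c2ccnc(-c3ccc(N(C)C)cc3)c2)c1` is assessed in a functional assay on SNB-75 cells (Homo sapiens) for cytotoxicity, read by sulforhodamine B assay, with a stated time of 48 h, tested at 0.001 uM (on this read-out higher numbers stand for a weaker effect at the one concentration tested and lower numbers for a stronger effect), and there gives 95%. Within the data shown here, it stands highest of the two numbers so far recorded. Among the measured compounds shown here, the nearest is compound 2 `COc1cc(C)cc(-c2nn(CC#N)cc2-c2ccc(-c3cccc(C(C)=O)c3)nc2)c1`, which in this assay gives 82%, a number lower by a gap that is beyond the usual scatter; no single-site step between these two is defined, so only the two values themselves are noted.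

Compound 3 `Cc1cc(O)cc(-c2nn(CC#N)cc2-c2ccnc(-c3ccc(N(C)C)cc3)c2)c1` has not been measured. It differs from compound 1 in one place: hydrogen in place of methyl on an oxygen on an aromatic ring. Read one bond further out, this is methoxy to hydroxy, or 3-methoxy-5-methylphenyl to 3-hydroxy-5-methylphenyl.

For the measured compounds named here, no measured step of this kind exists in the set, so the size of the step must be estimated from compound 1 alone. With compound 1 at 95% in this assay, the expectation is that the step of a number 2 percentage points lower from compound 1 to compound 3 (within the scatter) stays within the scatter, with no clear direction. Compound 3 is therefore expected to give about 93% in this assay, within a range of 80% to 105%.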

Compound 3, a percentage reported as activity, at one concentration (the size of the read-out at that concentration, not a potency): 83%
The estimate for compound 3 lay 10 percentage points above the measured number; the measured number falls inside the stated range.
By their numbers in this assay, from the lowest: compounds 2 and 3 (each within the scatter of the next); then compound 1.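

Hydrogen in place of methyl on the oxygen on the aromatic ring, methoxy to hydroxy, gives in this assay a number 12 percentage points lower from compound 1 to compound 3 (beyond the scatter), so this oxygen substituent is not silent in the series, and the change moves the read-out towards a stronger effect at the one concentration tested. Among these compounds, this is the first single-site step available, since the earlier pair offered only two values with no one-place difference between them, and the step is modest and rests on a single pair. Nothing measured on these compounds bears on why the number moves.

Open, going by these compounds, is whether the step comes with the free hydroxy itself or simply with the loss of the methyl, a question that a longer chain such as ethoxy, or an amine in the same place, would bear on. Also open, on these data alone, is whether the same methoxy to hydroxy change gives a step of similar size on the core of compound 2, and whether a read-out at one concentration reflects any change in potency.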